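Inverting the ring stereocentre of compound 2

The source may report more compounds than this note shows. Statements on the series, on what has been measured and on what is new or still open speak of the compounds shown alone.

In a functional assay on NCI-H630 cells (Homo sapiens) for cytotoxicity, read by sulforhodamine B assay, with a stated time of 5 days (on this read-out lower numbers stand for stronger inhibition and higher numbers for weaker inhibition), compound 2 `O=C(CCCCCCCCCc1ccccc1)CC(=O)N[C@@H]1CCOC1=O` gives > 100000 nM, which is a limit of the assay and not a number. Compound 3 `O=C(CCCCCCCCCc1ccccc1)CC(=O)N[C@H]1CCOC1=O` differs from compound 2 as follows: the two compounds have the same atoms and bonds and differ only in configuration as drawn: 1 of 1 stereo elements differ; a stereocentre at a saturated ring carbon is drawn R in compound 2 and S in compound 3. The expected move an at least 3.3-fold lower number from compound 2 to compound 3 (0.52 log units; beyond the scatter) runs towards stronger inhibition in this assay and beyond the scatter. For the measured compounds named here, this expectation rests on compound 1 `O=C(CCCCCCCCCCc1ccccc1)CC(=O)N[C@H]1CCOC1=O`, which gives 14000 nM as the only true number so far. For compound 3 the estimated value is 30000 nM with an expected range from 8000 nM to 100000 nM.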

Compound 3, half-maximal inhibitory concentration: 13000 nM
The estimate for compound 3 lay 2.3-fold (0.36 log units) above the measured number; the measured number falls inside the stated range.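

In this assay, drawing the ring stereocentre S rather than R gives an at least 7.6-fold lower number from compound 2 to compound 3 (0.88 log units; beyond the scatter), a step that can be assigned to that centre alone: the fact that compounds 2 and 3 differ only in the configuration as drawn

Compound 2 therefore gives only a limit and not a number, so the full size of the step stays unknown: the limit of > 100000 nM in this assay, at which 1 of the 3 values shown sits.

With the centre drawn S, phenyl in place of benzyl on a saturated chain carbon gives a 1.1-fold lower number from compound 1 to compound 3 (0.03 log units; within the scatter), so this chain change does not register. Still open, going by these compounds, is whether the S preference holds with a much shorter chain, or with a carboxylic acid in place of the terminal phenyl.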